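The compounds below may be only part of what the source reports. "The series", "measured", "known", "first", "only" and "open" are said of these compounds alone.

For the measured compounds named here, in a functional assay on SW-620 cells (Homo sapiens) for antiproliferative activity, read by MTT assay, with a stated time of 72 h (on this read-out lower numbers stand for stronger inhibition and higher numbers for weaker inhibition), compound 2 `CCCCCCCCC#Cc1cn(CCC(COC(C)=O)COC(C)=O)c(=O)n(C(=O)c2ccccc2)c1=O` gives 65800 nM, the one plain number among the two values shown. Compound 1 `CCCCCc1ccc(C#Cc2cn(CCC(COC(C)=O)COC(C)=O)c(=O)n(C(=O)c3ccccc3)c2=O)cc1` gives in this assay a limit, > 100000 nM, not a number. The step from compound 1 to compound 2 was an at least 1.5-fold lower number from compound 1 to compound 2 (0.18 log units; that floor lies within the scatter). Compound 3 `CC(=O)OCC(CCn1cc(C#CC(C)(C)C)c(=O)n(C(=O)c2ccccc2)c1=O)COC(C)=O` carries tert-butyl in place of octyl on a triple-bonded carbon. Going by the values given here, no measured step shortens a chain in this way, so that single measured step gives little guidance. The step of a 1.4-fold higher number from compound 2 to compound 3 (0.14 log units; within the scatter) that the estimate means is expected to stay within the scatter. Compound 3 is therefore estimated at 90000 nM, between 30000 nM and 300000 nM.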

Compound 3, half-maximal inhibitory concentration: > 100000 nM
Compound 3: only a limit was reported; the forecaster's own chance of this, stated with the estimate: 45%; middle value at least 1.1-fold (0.04 log units) away from the limit.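

With tert-butyl in place of octyl on the triple-bonded carbon, the result is an at least 1.5-fold higher number from compound 2 to compound 3 (0.18 log units; that floor lies within the scatter), so a much smaller group here gives no sign of stronger inhibition in this assay. The step between compound 1 and compound 3 cannot be read, as both values are limits. Most of this small set now sits at the same assay limit: the limit of > 100000 nM in this assay, at which 2 of the 3 values shown sit.

Compound 2 stands at 65800 nM. Going by these compounds, whether a longer chain, an amine or a carboxylic acid on this triple-bonded carbon would give a clearly lower number stays open.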